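The compounds below may be only part of what the source reports. "The series", "measured", "known", "first", "only" and "open" are said of these compounds alone.

Compound 1 `CCCCCCCCCCCCCCNC(=O)[C@@H](NC(=O)c1cc2ccccc2n1C)[C@@H](C)O` is the reference of this small set. In a functional assay on SW-620 cells (Homo sapiens) for cytotoxicity, read by MTT assay, with a stated time of 48 h (on this read-out lower numbers stand for stronger inhibition and higher numbers for weaker inhibition), compound 1 gives 21500 nM. Compound 2 `CCCCCCCCCCCCCCNC(=O)[C@@H](NC(=O)/C=C/c1ccccc1)[C@@H](C)O` differs from it by 2-phenylethenyl in place of 1-methyl-1H-indol-2-yl on a carbonyl carbon, and in this assay compound 2 gives 200000 nM, a step recorded as a 9.3-fold higher number from compound 1 to compound 2 (0.97 log units; beyond the scatter). Compound 3 `CCCCCCCCCCCCCCCCCCNC(=O)[C@@H](NC(=O)c1cc2ccccc2n1C)[C@@H](C)O` keeps the core of compound 1 but carries butyl in place of hydrogen on a saturated chain carbon, ten or more bonds along the chain from an amide-type nitrogen; in this assay compound 3 gives 124000 nM, which is a 5.8-fold higher number from compound 1 to compound 3 (0.76 log units; beyond the scatter). Compound 3 and compound 2 stand close to each other, their two numbers within the usual scatter of the read-out.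

Compound 4 `CCCCCCCCCCCCCCCCCCNC(=O)[C@@H](NC(=O)/C=C/c1ccccc1)[C@@H](C)O` is not yet measured. It differs from compound 3 by 2-phenylethenyl in place of 1-methyl-1H-indol-2-yl on a carbonyl carbon, the same change that took compound 1 to compound 2, at the same place. If that change acts alike on the core of compound 3, compound 4 is expected to land at a 3.6-fold higher number from compound 3 to compound 4 (0.56 log units; beyond the scatter), a step of about the size seen as a 9.3-fold higher number from compound 1 to compound 2 (0.97 log units; beyond the scatter), though compound 3 already sits near the upper end of the measured numbers, so the assay may report only a limit. On that basis compound 4 is estimated at 450000 nM, between 150000 nM and 1500000 nM.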

Compound 4, half-maximal inhibitory concentration: 200000 nM
Compound 4: middle estimate off by 2.3-fold (0.35 log units), on the high side; the measured number falls inside the stated range.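

In this assay, the change to 2-phenylethenyl on the carbonyl carbon now reads as a 1.6-fold higher number from compound 3 to compound 4 (0.21 log units; within the scatter), and the butyl change on the saturated chain reads as no change at the digits printed from compound 2 to compound 4 (within the scatter). The 2-phenylethenyl change therefore does not keep its size when carried from one core to the other: the same change on two cores in this assay, a 9.3-fold higher number (0.97 log units; beyond the scatter) from compound 1 to compound 2 and a 1.6-fold higher number (0.21 log units; within the scatter) from compound 3 to compound 4, 5.8-fold (0.76 log units) apart, beyond the scatter of two such steps. The butyl change behaves in the same way, but these two comparisons rest on the same four compounds in one cell assay, so they show that the steps do not simply add within this set and neither give a rule for the wider series nor explain the difference: the same change on two cores in this assay, a 5.8-fold higher number (0.76 log units; beyond the scatter) from compound 1 to compound 3 and no change at the digits printed (within the scatter) from compound 2 to compound 4, 5.8-fold (0.76 log units) apart, beyond the scatter of two such steps.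

The compounds shown leave open whether the same holds with a shorter chain, such as decyl, on the amide-type nitrogen. They also leave open how a plain phenyl group on the carbonyl carbon would behave on either core.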